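The source may report more compounds than this note shows. Statements on the series, on what has been measured and on what is new or still open speak of the compounds shown alone.

Working notes on the series. Values in a functional assay on SNB-19 cells (Homo sapiens) for inhibition, read by sulforhodamine B assay, with a stated time of 48 h; a lower number here means a stronger inhibitor of growth, a higher number a weaker inhibitor of growth:

Compound 1 `COc1cc(-c2cc(/C=C/C(=O)c3ccc(N)cc3)[nH]n2)cc(OC)c1OC`: 2340 nM
Compound 2 `COc1ccc(-c2cc(/C=C/C(=O)c3ccc(N)cc3)[nH]n2)cc1OC`: 4360 nM
Compound 3 `COc1cc(C(=O)/C=C/c2cc(-c3cc(OC)c(OC)c(OC)c3)n[nH]2)cc(OC)c1OC`: 1660 nM

Compound 1 and compound 2 differ by one change, (hydrogen in place of methoxy on an aromatic carbon), and it gave a 1.9-fold higher number from compound 1 to compound 2 (0.27 log units; within the scatter). Compound 3 stands with the lowest number of the three; against compound 1 the gap is within the scatter, against compound 2 beyond it. How the core of compound 3 differs from the core of compound 1 is not broken down here.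

Compound 4 `COc1ccc(-c2cc(/C=C/C(=O)c3cc(OC)c(OC)c(OC)c3)[nH]n2)cc1OC` has not yet been measured in this assay. It differs from compound 3 by hydrogen in place of methoxy on an aromatic carbon, the same change as from compound 1 to compound 2, with the surroundings of the place described in the same words. In this assay a step of about a 1.9-fold higher number from compound 3 to compound 4 (0.27 log units; within the scatter) is expected for compound 4, because the same change gave a 1.9-fold higher number from compound 1 to compound 2 (0.27 log units; within the scatter). Compound 4 is therefore estimated at 3100 nM, with a likely range from 1500 nM to 6500 nM.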

Compound 4, concentration for 50% growth inhibition: 1800 nM
Beside the measured number, compound 4's estimate is 1.7-fold (0.24 log units) above it; low and high end bracket the measured number.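

In this assay, hydrogen in place of methoxy gave a 1.1-fold higher number from compound 3 to compound 4 (0.04 log units; within the scatter). The steps on the two cores do not differ beyond the scatter: the same change on two cores in this assay, a 1.9-fold higher number (0.27 log units; within the scatter) from compound 1 to compound 2 and a 1.1-fold higher number (0.04 log units; within the scatter) from compound 3 to compound 4, 1.7-fold (0.24 log units) apart, within the scatter of two such steps. The change therefore carries from the core of compound 1 to the core of compound 3 without a detectable difference, but with two pairs, each step within the scatter, this does not show that the change has a real effect on either core, nor how it would behave on any other core.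

The compounds shown leave open whether a different group at this place, such as a hydroxyl, a fluorine or a longer chain like ethoxy, would move the number beyond the scatter.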